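The compounds below may be only part of what the source reports. "The series", "measured", "known", "first", "only" and "open" are said of these compounds alone.

Measured so far in a functional assay on CHO cells for agonist activity at Free fatty acid receptor 1 (Homo sapiens), read by a luciferase reporter; a lower number here means a smaller maximal response, a higher number a larger maximal response:

Compound 1, `Cc1nc(-c2ccc(C(F)(F)F)cc2)sc1CNc1ccc(CC(=O)O)cc1` — 18%
Compound 2, `Cc1nc(-c2ccc(C(F)(F)F)cc2)sc1CNc1ccc(OCC(=O)O)cc1` — 100%
Compound 3, `CC(C)NC(=O)CCc1ccc(NCc2cccc(Oc3ccccc3)c2)cc1` — 66%

Compound 2 gives the highest number of the three. Compound 3 comes nearest, and the gap between the two lies beyond the usual scatter; compound 1 lies furthest away. Compound 3 differs from compound 2 in several places at once, so its value only shows that a rather different molecule still reaches a sizeable response.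

The unmeasured compound 4, `Cc1nc(-c2ccc(C(F)(F)F)cc2)sc1CNc1ccc([C@H]2C[C@@H]2C(N)=O)cc1`, is built from compound 2 by one change on an aromatic carbon of the shared core: 2-carbamoylcyclopropyl in place of carboxymethoxy on an aromatic carbon. Within the data shown here, the only measured step that touches this spot is a number 82 percentage points higher from compound 1 to compound 2 (beyond the scatter), and it was large, showing that this assay reacts strongly to what hangs there. Compound 4 keeps neither the carboxymethoxy group nor the carboxymethyl group of compound 1, so a fall from compound 2 seems more likely than a rise, though how far is uncertain. The expected step is a number 55 percentage points lower from compound 2 to compound 4 (beyond the scatter). Compound 4 is therefore estimated at 45%, with a plausible range from 10% to 85%.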

Compound 4, largest response reached (reported as percent of maximum), in percent of the reference or control that the assay uses: 80%
Compound 4: middle estimate off by 35 percentage points, on the low side; low and high end bracket the measured number.
By their numbers in this assay, from the lowest: compound 1; then compound 3; then compound 4; then compound 2.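

In this assay, replacing carboxymethoxy with 2-carbamoylcyclopropyl on the aromatic carbon gives a modest change, with a number 20 percentage points lower from compound 2 to compound 4 (beyond the scatter), so a large maximal response at this position does not depend on keeping carboxymethoxy. The change from carboxymethyl to the same ring-bearing group gives a number 62 percentage points higher from compound 1 to compound 4 (beyond the scatter), a large step that places compound 4 much closer to compound 2 than to compound 1. Among these three compounds, a carboxylic acid at this position is neither enough for a large response, as compound 1 shows, nor required for a fairly large one, as compound 4 shows, although compound 2, which carries the acid, still gives the largest response of the three.

The compounds shown leave open whether the ring or the carbamoyl group matters more, a question that 2-carboxycyclopropyl, an unbranched propanamide chain, or the opposite stereoisomer of the 2-carbamoylcyclopropyl group could help to answer. No measurement given here explains why compound 4 keeps so much of the response.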